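A Methoxy-to-Bromo Swap on a Shared Core

A few compounds are considered here, and "the series" means these few. Any claim that something is new, unique, unknown or untested is made for them only; others in the source may bear on it.

Of the compounds shown here, two built on a shared core have been tested in a functional assay on SK-BR-3 cells (Homo sapiens) for antiproliferative activity, read by MTT assay, with a stated time of 72 h; a lower number here means a stronger inhibitor, a higher number a weaker inhibitor. Compound 1 `CCc1ccccc1C(=O)Nc1ccc2nc(N3CCN(CC)CC3)cc(C)c2c1` carries an ethyl group on the aromatic ring of its amide and gives 23900 nM in this assay. Compound 2 `CCN1CCN(c2cc(C)c3cc(NC(=O)c4ccccc4OC)ccc3n2)CC1` carries a methoxy group at that spot, and in this assay compound 2 gives 15700 nM. That change read a 1.5-fold lower number from compound 1 to compound 2 (0.18 log units; within the scatter). Compound 2 thus holds the lower of the two numbers, but compound 1 sits within the scatter of it, so no order between the two can be drawn.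

Compound 3 `CCN1CCN(c2cc(C)c3cc(NC(=O)c4ccccc4Br)ccc3n2)CC1` has not yet been measured. It differs from compound 2 by bromo in place of methoxy on an aromatic carbon. Going by the values given here, the only measured step at this position is the one between compound 1 and compound 2, which stayed within the scatter, and no measured step involves bromo at all. With that single step showing no change beyond the scatter, compound 3 is expected to land close to compound 2, the expected step being a 1.0-fold lower number from compound 2 to compound 3 (0.02 log units; within the scatter). Compound 3 is estimated at 15000 nM, with a range from 6000 nM to 40000 nM.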

Compound 3, half-maximal inhibitory concentration: 39200 nM
The estimate for compound 3 lay 2.6-fold (0.42 log units) below the measured number, within the range that was stated.
By their numbers in this assay, from the lowest: compounds 2, 1 and 3 (each within the scatter of the next, the first and the last beyond it).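

In this assay, this aromatic carbon now shows a step beyond the scatter, which the exchange of ethyl for methoxy did not: bromo in place of methoxy gives a modest change (a 2.5-fold higher number from compound 2 to compound 3 (0.40 log units; beyond the scatter)). Bromo in place of ethyl, by contrast, stays within the scatter (a 1.6-fold higher number from compound 1 to compound 3 (0.21 log units; within the scatter)), so compound 3 cannot be told apart from compound 1, and only compound 2 and compound 3 are separated by these numbers. The group on this carbon can therefore move the number in this assay, but only the exchange between methoxy and bromo does so here, and the effect is small.

As far as these compounds go, whether an amine, a carboxylic acid or a longer chain such as propyl on this carbon would shift the number further remains open, as does whether the step from 2-methoxyphenyl to 2-bromophenyl would be the same on another core. No measurement available here speaks to what lies behind the step from methoxy to bromo.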